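Selenium in place of sulfur in the series of compound 1

The compounds below may be only part of what the source reports. "The series", "measured", "known", "first", "only" and "open" are said of these compounds alone.

Compound 1 `CS/C(=N\C(=O)c1csc([N+](=O)[O-])c1)NC(=O)c1csc([N+](=O)[O-])c1` gives 56900 nM in a functional assay on K562 cells (Homo sapiens) for cytotoxicity, read by MTT assay, with a stated time of 72 h; a lower number here means a stronger inhibitor of growth, a higher number a weaker inhibitor of growth. Compound 3 `O=C(/N=C(/NC(=O)c1cc(-c2ccccc2)nc2ccccc12)[Se]Cc1ccccc1)c1cc(-c2ccccc2)nc2ccccc12` gives 9060 nM in this assay, a lower number than compound 1, and that gap lies beyond the scatter. In this assay compound 2 `CS/C(=N\C(=O)c1ccno1)NC(=O)c1ccno1` reaches the limit > 100000 nM; (the limit of > 100000 nM in this assay, at which 1 of the 3 values shown sits). Of the two numbers shown, compound 1 stands highest. Compound 4 `C[Se]/C(=N\C(=O)c1csc([N+](=O)[O-])c1)NC(=O)c1csc([N+](=O)[O-])c1` differs from compound 1 by a group of 2 heavy atoms (1 carbon, 1 selenium; no ring) in place of a group of 2 heavy atoms (1 carbon, 1 sulfur; no ring), on a carbon with a double bond to nitrogen. Among the compounds with values here, no measured pair carries this same change, so its size is open; compound 3 is the only measured selenium case and gives 9060 nM. The step from compound 1 to compound 4 is expected to be modest and downward, a 2.3-fold lower number from compound 1 to compound 4 (0.36 log units; beyond the scatter). For compound 4 the estimate is 25000 nM, between 8000 nM and 80000 nM.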

Compound 4, concentration for 50% growth inhibition: 4980 nM
Estimate against measurement, compound 4: 5.0-fold (0.70 log units) above; measured number outside the range, below it.
By their numbers in this assay, from the lowest: compounds 4 and 3 (each within the scatter of the next); then compound 1. At a limit, above all of these: compound 2.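

In this assay, methylsulfanyl giving way to its selenium counterpart on the carbon with a double bond to nitrogen produces an 11-fold lower number from compound 1 to compound 4 (1.06 log units; beyond the scatter). Within the data shown here, this is the first matched pair, and it shows that this position responds to the exchange of sulfur for selenium alone, with the rest of the core of compound 1 unchanged. Nothing at hand bears on the cause of this step.

On these data alone, whether the exchange carries over to other cores stays open. Also open, as far as these compounds go, is how a methoxy group, an amine or a longer chain on selenium would fare at this carbon.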